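Swapping the Benzodioxin Arm for a Methoxybenzyl Group

The source may hold more compounds than are shown below. What is called first, only, known or untested is meant among the compounds shown, and "the series" means these compounds.

Measured so far:
Compound 2, `O=S(=O)(NCCCNCC1COc2ccccc2O1)c1cc(C(F)(F)F)cc(C(F)(F)F)c1`: 2500 nM
Compound 1, `O=S(=O)(NCCNCc1cccc2ccccc12)c1cc(C(F)(F)F)cc(C(F)(F)F)c1`: 21000 nM

Both compounds were tested in a functional assay on Capan-2 cells (Homo sapiens) for inhibition, read by MTT assay, with a stated time of 72 h; a lower number here means a stronger inhibitor of growth, a higher number a weaker inhibitor of growth. Compound 2 stands at the lower of the two numbers, and its gap to compound 1 lies beyond the usual scatter of this assay. Compound 1 differs from compound 2 in more than one place, in the length of the chain and in the ring system on the amine side, so no single structural step can be read from that pair.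

Compound 3, `COc1ccccc1CNCCCNS(=O)(=O)c1cc(C(F)(F)F)cc(C(F)(F)F)c1`, differs from compound 2 in one place only: 2-methoxyphenyl in place of 2,3-dihydro-1,4-benzodioxin-2-yl on a saturated chain carbon bound to an amine nitrogen. The group that leaves carries one six-membered non-aromatic ring with 2 hetero atoms fused to the aromatic ring; the group that enters keeps one aromatic ring with a single oxygen.

Going by the values given here, no step between compounds that differ in one place has been measured, so no size can be borrowed. The step in this assay is expected to be small, a modest weakening at most, close to the scatter. The estimated step of a 1.6-fold higher number from compound 2 to compound 3 (0.20 log units; within the scatter) reflects this. Compound 3 is expected to give about 4000 nM, within a range of 1500 nM to 12000 nM.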

Compound 3, concentration for 50% growth inhibition: 6000 nM
Estimate against measurement, compound 3: 1.5-fold (0.18 log units) below; the range from low to high includes it.
By their numbers in this assay, from the lowest: compound 2; then compound 3; then compound 1.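

Going by these compounds alone, measured in this assay the swap of 2,3-dihydro-1,4-benzodioxin-2-yl for 2-methoxyphenyl on a saturated chain carbon bound to an amine nitrogen is the first change that can be read on its own, and it comes to a 2.4-fold higher number from compound 2 to compound 3 (0.38 log units; beyond the scatter) with only this one place altered. This place therefore responds to the group it carries, yet the response is modest: compound 3 has one aromatic ring and a single oxygen in this group, without the six-membered non-aromatic ring, and it still inhibits growth in the same low range as compound 2. Nothing measured in this set accounts for the difference between the two groups.

Because the ring and the second oxygen leave together, this one step cannot say which of them matters, and a plain benzyl group or a 2-hydroxybenzyl group at this place would be needed to pull them apart. Going by these compounds, compound 1 differs from both other compounds in more than one place, so its steps cannot be read, and the effect of a longer or shorter chain on its own stays open.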